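Changing the Benzyl Group on a Shared Core

The source may hold more compounds than are shown below. What is called first, only, known or untested is meant among the compounds shown, and "the series" means these compounds.

Compound 1, `Cc1ccc(CSc2cc(Cl)c(C)cc2S(=O)(=O)/N=C(\N)n2nc(C)cc2-c2ccccc2)cc1`: 28000 nM
Compound 2, `Cc1cccc(CSc2cc(Cl)c(C)cc2S(=O)(=O)/N=C(\N)n2nc(C)cc2-c2ccccc2)c1`: 34000 nM
Compound 3, `Cc1cc(-c2ccccc2)n(/C(N)=N/S(=O)(=O)c2cc(C)c(Cl)cc2SCc2ccc(Cl)cc2)n1`: 7000 nM

These three compounds were tested in a functional assay on HCT-116 cells (Homo sapiens) for cytotoxicity, read by MTT assay, with a stated time of 72 h; on this read-out higher numbers stand for weaker inhibition and lower numbers for stronger inhibition. Compound 3 stands lowest of the three numbers, that is, it inhibits the cells most strongly: a 4.0-fold lower number from compound 1 to compound 3 (0.60 log units; beyond the scatter) and a 4.9-fold lower number from compound 2 to compound 3 (0.69 log units; beyond the scatter), both beyond the usual scatter. Compound 4, `Cc1cc(-c2ccccc2)n(/C(N)=N/S(=O)(=O)c2cc(C)c(Cl)cc2SCc2ccccc2C(F)(F)F)n1`, is the next step from compound 3, and the change is 2-(trifluoromethyl)phenyl in place of 4-chlorophenyl on a saturated chain carbon bound to a sulfur.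

Among the measured compounds shown here, two measured steps bear on this change, both at the same place on the molecule. Moving a methyl group around the ring gave a 1.2-fold higher number from compound 1 to compound 2 (0.08 log units; within the scatter), a change too small to count. Replacing 3-methylphenyl by 4-chlorophenyl gave a 4.9-fold lower number from compound 2 to compound 3 (0.69 log units; beyond the scatter), a modest gain. For the measured compounds named here, no measured compound carries a trifluoromethyl group or a 2-substituted benzyl, so the new group has no direct precedent here. Since the gain seen in compound 3 came with the chlorine that now leaves, the expectation is a modest weakening, a 2.0-fold higher number from compound 3 to compound 4 (0.30 log units; within the scatter). Compound 4 is therefore estimated at 14000 nM, with a range from 4000 nM to 45000 nM.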

Compound 4, half-maximal inhibitory concentration: 25000 nM
Compound 4: middle estimate off by 1.8-fold (0.25 log units), on the low side; the measured number falls inside the stated range.
By their numbers in this assay, from the lowest: compound 3; then compounds 4, 1 and 2 (each within the scatter of the next).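

In this assay, the 4-chlorophenyl of compound 3 gains no support from a second halogen-bearing or fluorine-bearing ring at this position: 2-(trifluoromethyl)phenyl in its place gives a modest loss (a 3.6-fold higher number from compound 3 to compound 4 (0.55 log units; beyond the scatter)). The new group also does not separate from the methyl-bearing rings (a 1.4-fold lower number from compound 2 to compound 4 (0.13 log units; within the scatter); a 1.1-fold lower number from compound 1 to compound 4 (0.05 log units; within the scatter)), so compounds 1, 2 and 4 sit together within the scatter, and compound 3 alone stands apart from them. Nothing available here explains why compound 3 stands apart.

This step swaps the substituent and its ring position at once, so the two cannot be told apart. From the compounds shown here alone, a pairing of 4-(trifluoromethyl)phenyl with 2-chlorophenyl would separate them, and a ring bearing an amine or a carboxylic acid remains open too.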